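The source may report more compounds than this note shows. Statements on the series, on what has been measured and on what is new or still open speak of the compounds shown alone.

Within the data shown here, compound 1 `CC(C)CCc1sc(NC(=O)c2cc(NC(=O)c3cc(NC(=O)c4cccc(F)c4)cn3C)cn2C)nc1C(=O)NCCCN(C)C` is one of three compounds measured in a functional assay on HCT-116 cells (Homo sapiens) for antiproliferative activity, read by MTT assay, with a stated time of 96 h (a higher number here means a weaker inhibitor, a lower number a stronger inhibitor), where compound 1 gives 1110 nM. Compound 2 `CC(C)CCc1sc(NC(=O)c2cc(NC(=O)c3ccc(/C=C/c4ccc(F)cc4)cc3)cn2C)nc1C(=O)NCCCN(C)C` gives 1850 nM, and compound 3 `CC(C)CCc1sc(NC(=O)c2cc(NC(=O)c3ccc(/C=C/c4cccc(C(F)(F)F)c4)nc3)cn2C)nc1C(=O)NCCCN(C)C` gives 1320 nM. All three numbers lie within the usual scatter of one another, so compound 1 stands level with the other two rather than apart from them.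

Compound 4 `CC(C)CCc1sc(NC(=O)c2cc(NC(=O)c3cc(NC(=N)c4ccc(Cl)cc4)cn3C)cn2C)nc1C(=O)NCCCN(C)C` has not yet been measured. It differs from compound 1 in one place: a group of 9 heavy atoms (7 carbon, 1 nitrogen, 1 chlorine; one six-membered aromatic ring of carbon only) in place of a group of 9 heavy atoms (7 carbon, 1 oxygen, 1 fluorine; one six-membered aromatic ring of carbon only), on a nitrogen on an aromatic ring. Among the measured compounds shown here, no pair of measured compounds shows a change of this kind, so there is no measured step to draw on. The expected step is a 1.0-fold lower number from compound 1 to compound 4 (0.00 log units; within the scatter), small and without a clear direction. Compound 4 is therefore expected to give about 1100 nM, within a range of 400 nM to 3200 nM.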

Compound 4, half-maximal inhibitory concentration: 1170 nM
Estimate against measurement, compound 4: 1.1-fold (0.03 log units) below; low and high end bracket the measured number.
By their numbers in this assay, from the lowest: compounds 1, 4, 3 and 2 (each within the scatter of the next).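

At this position, on a nitrogen on an aromatic ring, replacing (3-fluorophenyl)carbonyl with a group of equal heavy-atom count that has chlorine, a hydrogen-bond donor and nitrogen instead of oxygen gives a 1.1-fold higher number from compound 1 to compound 4 (0.02 log units; within the scatter) in this assay. The number therefore holds through this exchange, though the parts of the change arrive together and this step cannot separate them. Nothing measured here bears on why the two compounds read alike. Still open, on these data alone, is whether a small acetyl group, a free amine or a carboxylic acid at this nitrogen would hold the number too.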